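The compounds below may be only part of what the source reports. "The series", "measured", "known", "first", "only" and "open" are said of these compounds alone.

Measured so far:
- Compound 1 `Nc1cccn2cc(Cc3ccccc3)c(=O)nc12`: 112000 nM
- Compound 2 `O=C1N=C2C=CC=CN2CC1C(O)c1cccs1`: 166000 nM

In a functional assay on HeLa cells (Homo sapiens) for cytotoxicity, read by MTT assay, with a stated time of 24 h (on this read-out lower numbers stand for stronger inhibition and higher numbers for weaker inhibition), compound 1 gives 112000 nM and compound 2 gives 166000 nM. These two values lie within the usual scatter of each other, so compound 1 cannot be ranked ahead of compound 2 or behind it.

The next compound to be tested is compound 3 `Nc1cccn2cc(Cc3ccc(F)cc3)c(=O)nc12`. It keeps the core of compound 1 and differs in one place: fluoro in place of hydrogen on an aromatic carbon. This is fluoro in place of hydrogen on an aromatic carbon, para to a large group.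

Within the data shown here, no measured pair of compounds shows this kind of change, so the data offer no direct guide to its effect. Among the measured compounds shown here, the only close reference is compound 1 at 112000 nM, and no shift beyond the scatter is expected in this assay, in either direction. The expected step is small: a 1.1-fold lower number from compound 1 to compound 3 (0.05 log units; within the scatter). For compound 3, the estimated value is 100000 nM, with an expected range from 45000 nM to 220000 nM.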

Compound 3, half-maximal inhibitory concentration: > 1000000 nM
Compound 3 ended at the assay's limit; the forecaster's own chance of this, stated with the estimate: 10%; at least 10-fold (1.00 log units) between middle value and limit.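

Compound 3 gives > 1000000 nM, which is a limit of the assay and not a number. The earlier compounds shown here offered no step to read, but this pair shows that the aromatic carbon para to a large group is sensitive to substitution: in this assay, fluoro in place of hydrogen, an exchange of a single heavy atom for a hydrogen atom, gives an at least 8.9-fold higher number from compound 1 to compound 3 (0.95 log units; beyond the scatter), which means weaker inhibition. This step marks only the smallest possible change and not its full size, because the value of compound 3 sits at the end of the range that can be read: the limit of > 1000000 nM in this assay, at which 1 of the 3 values shown sits.

Going by these compounds, whether this effect belongs to fluoro itself or would follow any group placed there stays open, since one pair cannot separate the two, and a chloro or a methoxy group on the same aromatic carbon would be needed to tell them apart. The compounds shown also leave open whether the same exchange would act alike on other aromatic carbons of this ring, and they give no cause for the effect.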